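The source may hold more compounds than are shown below. What is called first, only, known or untested is meant among the compounds shown, and "the series" means these compounds.

Working notes on the series, read in a functional assay on SGC-7901 cells (Homo sapiens) for antiproliferative activity, read by MTT assay, with a stated time of 72 h; on this read-out lower numbers stand for stronger inhibition and higher numbers for weaker inhibition. Compound 1 (`COc1cc(-n2cnc3ccc(-c4ccc(C(C)=O)cc4)cc32)cc(OC)c1OC`) gives 450 nM, compound 2 (`COc1cc(-n2cnc3ccc(-c4ccc(C)cc4F)cc32)cc(OC)c1OC`) gives 5650 nM, and compound 3 (`COc1cc(-n2cnc3ccc(-c4ccc(Cl)cc4)cc32)cc(OC)c1OC`) gives 1270 nM. Compound 3 therefore holds the middle of the three numbers. Compound 4 (`COc1cc(-n2cnc3ccc(-c4ccc(O)cc4)cc32)cc(OC)c1OC`) is still unmeasured and has hydroxy in place of chloro on an aromatic carbon, para to a large group: hydroxy in place of chloro on an aromatic carbon. Among the measured compounds shown here, no measured step tests hydroxy directly. The nearest evidence is a 2.8-fold higher number from compound 1 to compound 3 (0.45 log units; beyond the scatter), a modest step with chloro in place of acetyl on an aromatic carbon. The other two steps, a 4.4-fold lower number from compound 2 to compound 3 (0.65 log units; beyond the scatter) and a 13-fold higher number from compound 1 to compound 2 (1.10 log units; beyond the scatter), show that changes on this outer ring can also move the number by a modest to large amount. A modest shift at most is expected here, leaning towards a lower number and possibly staying within the scatter. The expected step is a 1.6-fold lower number from compound 3 to compound 4 (0.20 log units; within the scatter). For compound 4 the estimated value is 800 nM, with an expected range of 250 nM to 2500 nM.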

Compound 4, half-maximal inhibitory concentration: > 10000 nM
Compound 4 was reported as a limit; the forecaster's own chance of this, stated with the estimate: 2%; at least 12-fold (1.09 log units) between middle value and limit.
By their numbers in this assay, from the lowest: compound 1; then compound 3; then compound 2. At a limit, above all of these: compound 4.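

In this assay compound 4 is reported only as a limit, not as a number: the limit of > 10000 nM in this assay, at which 1 of the 4 values shown sits.

Hydroxy in place of chloro, para to a large group, gives an at least 7.8-fold higher number from compound 3 to compound 4 (0.89 log units; beyond the scatter), so exchanging one heavy atom here can move the number far more than the earlier compounds suggested, with a hydrogen-bond donor entering at this place. Hydroxy in place of acetyl gives an at least 22-fold higher number from compound 1 to compound 4 (1.34 log units; beyond the scatter), while 4-hydroxyphenyl in place of 2-fluoro-4-methylphenyl gives an at least 1.7-fold higher number from compound 2 to compound 4 (0.24 log units; that floor lies within the scatter), so only the floor of that last step is known, and it does not clear the scatter.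

The compounds shown do not separate the hydrogen-bond donor from the oxygen atom itself, as methoxy or an amine at this place could. On these data alone, how far compound 4 lies past its limit also remains open.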